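Methoxy for fluoro on the aryl ring of compound 2

A few compounds are considered here, and "the series" means these few. Any claim that something is new, unique, unknown or untested is made for them only; others in the source may bear on it.

Measured so far: compound 1 `O=C1CSC(c2cccc(O)c2)N1CCN1CCCCC1` gives 100%; compound 2 `O=C1CSC(c2cccc(F)c2)N1CCN1CCCCC1` gives 92%.

In an ADME assay on Vero cells (Chlorocebus sabaeus) for cytotoxicity, read by neutral red uptake, tested at 98 ug/mL (on this read-out higher numbers stand for a weaker effect at the one concentration tested and lower numbers for a stronger effect), compound 2 stands lowest of the two numbers, with compound 1 nearest and within the scatter of it. Compound 3 `COc1cccc(C2SCC(=O)N2CCN2CCCCC2)c1` is not yet measured. It differs from compound 2 thus: methoxy in place of fluoro on an aromatic carbon. Within the data shown here, the one measured step that bears on this place, a number 8 percentage points lower from compound 1 to compound 2 (within the scatter), was within the scatter, so no step beyond the scatter is expected from compound 2 to compound 3. Compound 3 is therefore expected to give 95%, within 80% to 100%, an expected step of a number 3 percentage points higher from compound 2 to compound 3 (within the scatter).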

Compound 3, a percentage reported as activity, at one concentration (the size of the read-out at that concentration, not a potency): 84%
Beside the measured number, compound 3's estimate is 11 percentage points above it; low and high end bracket the measured number.
By their numbers in this assay, from the lowest: compounds 3, 2 and 1 (each within the scatter of the next, the first and the last beyond it).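

In this assay, among these compounds, the methyl on the oxygen brings the first step beyond the scatter at this place, with a number 16 percentage points lower from compound 1 to compound 3 (beyond the scatter) as the result. Methoxy in place of fluoro, by contrast, gives a number 8 percentage points lower from compound 2 to compound 3 (within the scatter) and leaves compound 2 within the scatter of both compound 1 and compound 3. Nothing measured here gives a reason for these steps. The compounds shown leave open whether an amine or a carboxylic acid on this aromatic carbon would move the number further, and whether a longer chain on the oxygen, such as ethoxy, would go beyond methoxy.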